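Chlorobenzyl isomers on a cyclic sulfonamide core

A few compounds are considered here, and "the series" means these few. Any claim that something is new, unique, unknown or untested is made for them only; others in the source may bear on it.

Measured so far in a functional assay on CCRF-CEM cells (Homo sapiens) for inhibition; on this read-out higher numbers stand for lower toxicity in this test and lower numbers for higher toxicity in this test:
Compound 1 `O=C1c2ccccc2N(Cc2ccccc2)S(=O)(=O)N1COCc1ccccc1`: 100000 nM
Compound 2 `O=S1(=O)N=C(OCc2ccccc2)c2ccccc2N1Cc1ccccc1`: 22200 nM
Compound 3 `O=C1c2ccccc2N(Cc2ccc(Cl)cc2)S(=O)(=O)N1Cc1ccccc1`: 19700 nM

Compound 3 gives the lowest of the three numbers. Its gap to compound 2 lies within the scatter, while its gap to compound 1 lies beyond it. Compound 4 `O=C1c2ccccc2N(Cc2cccc(Cl)c2)S(=O)(=O)N1Cc1ccccc1` differs from compound 3 in one place: 3-chlorophenyl in place of 4-chlorophenyl on a saturated chain carbon bound to a sulfonamide nitrogen in a ring. Among the compounds with values here, no pair of measured compounds differing in a single place is available, so no size can be read from the data for such a change. A step from compound 3 to compound 4 of no more than the scatter is expected, in either direction. Compound 4 is estimated to give 20000 nM in this assay, with a range from 8000 nM to 50000 nM. This estimate means a step of a 1.0-fold higher number from compound 3 to compound 4 (0.01 log units; within the scatter), expected to stay within the scatter.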

Compound 4, half-maximal cytotoxic concentration: 2100000 nM
Beside the measured number, compound 4's estimate is 110-fold (2.02 log units) below it; measured number above the stated range.
By their numbers in this assay, from the lowest: compounds 3 and 2 (each within the scatter of the next); then compound 1; then compound 4.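

In this assay, within the data shown here, 3-chlorophenyl in place of 4-chlorophenyl gives a 110-fold higher number from compound 3 to compound 4 (2.03 log units; beyond the scatter), the only single-place step. The same atoms, joined differently, are thus enough to produce a large change at this place, on a saturated chain carbon bound to a sulfonamide nitrogen in a ring, toward lower toxicity in this test. Nothing available bears on the cause of this step. 

From the compounds shown here alone, it remains open where plain benzyl or methoxybenzyl at this place would fall relative to compound 3 and compound 4. Going by these compounds, whether the same change on the other benzyl group gives a step of similar size is also open.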